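The source may report more compounds than this note shows. Statements on the series, on what has been measured and on what is new or still open speak of the compounds shown alone.

The measured compounds in an ADME assay on HCT-116 cells (Homo sapiens) for cytotoxicity, read by MTT assay, with a stated time of 72 h; on this read-out lower numbers stand for stronger inhibition and higher numbers for weaker inhibition:

Compound 1, `CCc1ccc(NC(=O)c2cccc(/C=C3\CC(=O)N(c4ccccc4)C3=O)c2)cc1`, gives > 100000 nM, a limit of the assay rather than a number.
Compound 2, `COc1ccc(NC(=O)c2cccc(/C=C3\CC(=O)N(c4ccc(C)cc4)C3=O)c2)cc1`, gives > 100000 nM, again only a limit of the assay.
Compound 3, `CCCCCN1C(=O)C/C(=C\c2cccc(C(=O)Nc3ccc(OC)cc3)c2)C1=O`, gives > 100000 nM, likewise only a limit.

Where compound 1 stands on the numbers shown is therefore not a rank but a limit: all three measured compounds sit at the same limit, as the limit of > 100000 nM in this assay, at which 3 of the 3 values shown sit, records, and nothing places compound 1 above or below its two companions. Among the measured compounds shown here, the one step between measured compounds that differ in a single place, a step that the two limits leave unreadable from compound 2 to compound 3, is left unreadable by the two limits, so no size can be read from it.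

The piece now follows the step from compound 1 to compound 4, `O=C(Nc1ccc(F)cc1)c1cccc(/C=C2\CC(=O)N(c3ccccc3)C2=O)c1`, which is to be measured in this assay. The change is fluoro in place of ethyl on an aromatic carbon. For the measured compounds named here, no measured step touches this exchange of ethyl for fluoro; the only measured step, from compound 2 to compound 3, concerns a different position and is itself unreadable. With every measured value at the limit, the expectation for compound 4 is that the assay again reports no number beyond the limit, so the step of a number no higher from compound 1 to compound 4 (the limit leaves the size open) is expected to be none beyond the scatter. The estimate for compound 4 is 100000 nM, with a range from 30000 nM to 300000 nM.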

Compound 4, half-maximal inhibitory concentration: > 100000 nM
Compound 4 ended at the assay's limit; the forecaster's own chance of this, stated with the estimate: 85%; the middle value sits exactly at the limit.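

In this assay compound 4 gives > 100000 nM, a limit of the assay and not a number. Compound 1 also stands only at a limit, and no step can be read between compound 1 and compound 4. The compounds shown leave open whether any change to them would yield an actual number in this assay, with every value at one limit: the limit of > 100000 nM in this assay, at which 4 of the 4 values shown sit.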